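The source may report more compounds than this note shows. Statements on the series, on what has been measured and on what is new or still open speak of the compounds shown alone.

Among the compounds with values here, compound 2 `O=[N+]([O-])c1cccc(-c2csc(N/N=C/c3ccc(C(F)(F)F)cc3)n2)c1` is one of only two compounds measured in an ADME assay on PBMC cells (Homo sapiens) for inhibition, read by resazurin assay, with a stated time of 72 h; a higher number here means a weaker inhibitor, a lower number a stronger inhibitor. In this assay compound 2 gives 151000 nM, the highest of the two numbers, meaning the weaker inhibitor of the pair. The other compound, compound 1 `O=[N+]([O-])c1ccc(-c2csc(N/N=C/c3ccc(C(F)(F)F)cc3)n2)cc1`, gives 53200 nM in this assay. Within the data shown here, the single step measured so far, a 2.8-fold higher number from compound 1 to compound 2 (0.45 log units; beyond the scatter), concerns only where the nitro group sits on the phenyl ring.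

Compound 3 `FC(F)(F)c1ccc(/C=N/Nc2nc(-c3ccc(Cl)cc3Cl)cs2)cc1` differs from compound 2 in another way: 2,4-dichlorophenyl in place of 3-nitrophenyl on an aromatic carbon. Among the measured compounds shown here, no measured step bears on this exchange; the one step available moved the nitro group rather than removing it, so it offers no direction for compound 3. Without any guiding step, the expectation for compound 3 is a step of a 1.5-fold lower number from compound 2 to compound 3 (0.18 log units; within the scatter), which is no change beyond the scatter, held with low confidence and a wide range. The estimate for compound 3 in this assay is therefore 100000 nM, expected to fall between 25000 nM and 400000 nM.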

Compound 3, half-maximal inhibitory concentration: 43000 nM
Compound 3: the middle estimate sits 2.3-fold (0.37 log units) above what was measured; low and high end bracket the measured number.
By their numbers in this assay, from the lowest: compounds 3 and 1 (each within the scatter of the next); then compound 2.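

On the aromatic carbon next to the ring nitrogen, the exchange of a nitrophenyl for 2,4-dichlorophenyl has now been tested, and the outcome in this assay depends on which nitrophenyl is replaced. Starting from the 3-nitrophenyl group, the exchange gives a 3.5-fold lower number from compound 2 to compound 3 (0.55 log units; beyond the scatter), whereas starting from the 4-nitrophenyl group it gives a 1.2-fold lower number from compound 1 to compound 3 (0.09 log units; within the scatter), a difference that stays within the scatter. A nitro group is therefore not required at this position to reach the numbers seen for compound 1, since a phenyl ring carrying two chlorines instead does as well, and nothing available explains these differences.

Compound 3 places chlorine on the phenyl ring at two positions at once, so these compounds cannot show what either chlorine contributes alone, or whether a phenyl ring with no substituent at all would give a similar number. They also leave open how a quite different group on that ring, such as an amine or a carboxylic acid, would behave in this assay.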